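Benzyl in place of 4-methylphenyl on the amine nitrogen

This account rests on a few compounds, and the source may have more. Where it says the series, first, only, none or still open, it means among the compounds named here.

Of the compounds shown here, three sharing one core have been measured in a functional assay on MCF7 cells (Homo sapiens) for inhibition, read by sulforhodamine B assay; a higher number here means a weaker inhibitor, a lower number a stronger inhibitor. Compound 1 `O=C1C=C(Nc2ccc(I)cc2)C(=O)c2c1nc1n2[C@H]2OC[C@@H](O)[C@H]2OC1` gives 2230 nM, compound 2 `Cc1ccc(NC2=CC(=O)c3nc4n(c3C2=O)[C@H]2OC[C@@H](O)[C@H]2OC4)cc1` gives 1660 nM, and compound 3 `O=C1C(Nc2cccc(Cl)c2)=CC(=O)c2c1nc1n2[C@H]2OC[C@@H](O)[C@H]2OC1` gives 2970 nM. Compound 2 holds the lowest of the three numbers, yet its distance to compound 1 and to compound 3 lies within the scatter, so no order among them can be claimed. Among the compounds with values here, the only step between compounds that differ in a single place, a 1.3-fold lower number from compound 1 to compound 2 (0.13 log units; within the scatter), changes nothing beyond the scatter.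

Compound 4 `O=C1C=C(NCc2ccccc2)C(=O)c2c1nc1n2[C@H]2OC[C@@H](O)[C@H]2OC1` is not yet measured. It differs from compound 2 in one place: benzyl in place of 4-methylphenyl on an amine nitrogen. Within the data shown here, no measured step touches a change of this kind; the step from compound 1 to compound 2 alters a group on the aromatic ring while the link from ring to nitrogen stays as it was, so it offers only the observation that one change at this end of the molecule left this assay nearly unmoved. Lacking a guide for the altered link, compound 4 is expected to give a number close to that of compound 2, with a wide range on either side. The estimated step of a 1.5-fold higher number from compound 2 to compound 4 (0.18 log units; within the scatter) is expected to remain within the scatter. Compound 4 is estimated at 2500 nM, between 900 nM and 8000 nM.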

Compound 4, half-maximal inhibitory concentration: > 8000 nM
Compound 4: only a limit was reported (the forecaster's own chance of this, stated with the estimate: 10%); middle value at least 3.2-fold (0.50 log units) away from the limit.
By their numbers in this assay, from the lowest: compounds 2, 1 and 3 (each within the scatter of the next). At a limit, above all of these: compound 4.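

In this assay compound 4 gives > 8000 nM, which is a limit of the assay and not a number: the limit of > 8000 nM in this assay, at which 1 of the 4 values shown sits.

Benzyl on the amine nitrogen holds the same atoms as 4-methylphenyl, joined differently, and it gives an at least 4.8-fold higher number from compound 2 to compound 4 (0.68 log units; beyond the scatter); set against 4-iodophenyl it gives an at least 3.5-fold higher number from compound 1 to compound 4 (0.55 log units; beyond the scatter). Both steps lie beyond the scatter, whereas changing the group on the aromatic ring with the link to nitrogen left intact gave a 1.3-fold lower number from compound 1 to compound 2 (0.13 log units; within the scatter), so among these compounds the link itself, rather than that ring group, is what moves the number.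

Going by these compounds, how far compound 4 lies past its limit stays unknown. Also open, on these data alone, is whether 4-methylbenzyl, a longer chain such as phenethyl, or a cyclohexyl group on the amine nitrogen would behave like benzyl.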